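This account rests on a few compounds, and the source may have more. Where it says the series, first, only, none or still open, it means among the compounds named here.

Measured so far in a functional assay on the whole organism for inhibition, with Chenopodium ficifolium as the target, with a stated time of 72 h, tested at 10 mg/L; on this read-out higher numbers stand for more inhibition of growth at the one concentration tested and lower numbers for less inhibition of growth:
compound 1 `COc1cc(C)nc2n/c(=N/C(=O)c3c(-c4ccc(Cl)cc4Cl)noc3C)sn12` gives 45.7%;
compound 2 `COc1cc(SC)nc(NC(=S)NC(=O)c2c(-c3ccc(Cl)cc3Cl)noc2C)n1` gives -8.31%;
compound 3 `Cc1cc(Cl)nc(NC(=S)NC(=O)c2c(-c3ccc(Cl)cc3Cl)noc2C)n1` gives 28.9%.

Compound 1 stands highest of the three numbers. Its nearest neighbour is compound 3, lower by a margin beyond the scatter, and compound 2 lies furthest, also beyond the scatter. Within the data shown here, only one pair differs in a single place: a number 37.2 percentage points higher from compound 2 to compound 3 (beyond the scatter), a large step. Compounds 2 and 3 share a core that is not the fused core of compound 1, and the change between them exchanges two groups on the six-membered ring at once, so this step bears on compound 4 only loosely.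

Compound 4 `COc1cc(OC)n2s/c(=N\C(=O)c3c(-c4ccc(Cl)cc4Cl)noc3C)nc2n1` differs from compound 1 by methoxy in place of methyl on an aromatic carbon. Among the measured compounds shown here, no measured step covers this exact change on the core of compound 1. What the step from compound 2 to compound 3 does show is that small substituent exchanges on the six-membered ring can move this assay a great deal, and in that pair the compound carrying a methoxy group, compound 2, is the lower one. A moderate decrease is therefore expected for compound 4, of about a number 11.7 percentage points lower from compound 1 to compound 4 (beyond the scatter), with wide uncertainty. The estimate for compound 4 is 34%, in the range 8% to 58%.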

Compound 4, percent growth inhibition at one concentration: 28.9%
The estimate for compound 4 lay 5.1 percentage points above the measured number; low and high end bracket the measured number.
By their numbers in this assay, from the lowest: compound 2; then compounds 3 and 4 (each within the scatter of the next); then compound 1.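

In this assay, the position on the six-membered aromatic ring of the core of compound 1 proves sensitive to a single exchange, with methoxy in place of methyl on an aromatic carbon: a number 16.8 percentage points lower from compound 1 to compound 4 (beyond the scatter). Among these compounds, this is the first step read on this core, as the earlier step belonged to the different core shared by compound 2 and compound 3 and exchanged two groups at once, so a change at one ring position is now seen to matter on its own, though the size of this step is modest and growth inhibition is not lost, with compound 4 at 28.9%. Nothing measured here accounts for the drop, and no data on the properties of these compounds bear on it.

The compounds shown leave open whether the lower number is particular to methoxy or would follow from other replacements of this methyl, such as an amine, a chlorine atom or a longer chain like ethyl. A single step on this core also leaves open whether the same exchange would move the number similarly in other members of the series.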